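From a methyl-oxazole to a pyridine on the shared core

The compounds below may be only part of what the source reports. "The series", "measured", "known", "first", "only" and "open" are said of these compounds alone.

Compound 3 `Cc1cc(-c2cc(-c3cc(O)c(O)c([N+](=O)[O-])c3)on2)on1` stands second highest of three in a functional assay on the whole organism (liver, strain NMRI) for inhibition, with Mus musculus as the target, with a stated time of 3 h, at a dose of 3 mg/kg by the oral route (a higher number here means more inhibition at the dose given (going by the name of the read-out), a lower number less inhibition), where compound 3 gives 32.4%. Its nearest neighbour, compound 2 `Cc1nc(-c2noc(-c3cc(O)c(O)c([N+](=O)[O-])c3)n2)cs1`, gives 22.9%, a gap within the scatter, while the furthest, compound 1 `CN1CCN(c2noc(-c3cc(O)c(O)c([N+](=O)[O-])c3)n2)CC1`, gives 56.8%, a gap beyond the scatter. Compound 4 `O=[N+]([O-])c1cc(-c2cc(-c3ccncc3)no2)cc(O)c1O` differs from compound 3 by pyridin-4-yl in place of 3-methyl-1,2-oxazol-5-yl on an aromatic carbon. Among the measured compounds shown here, the only measured step, a number 33.9 percentage points lower from compound 1 to compound 2 (beyond the scatter), replaced one attached group by another on a different core and was large, but it does not cover this particular exchange, so it gives little guidance. Compound 4 is therefore expected to show a step of about a number 2.4 percentage points lower from compound 3 to compound 4 (within the scatter), within the scatter. The estimate for compound 4 is 30%, with a range from 10% to 55%.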

Compound 4, a percentage reported as inhibition, in the whole organism at one dose (the size of the read-out at that dose, not a potency): 32.1%
Beside the measured number, compound 4's estimate is 2.1 percentage points below it, within the range that was stated.
By their numbers in this assay, from the lowest: compounds 2, 4 and 3 (each within the scatter of the next); then compound 1.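

In this assay, placing pyridin-4-yl on this aromatic carbon instead of 3-methyl-1,2-oxazol-5-yl gives a number 0.3 percentage points lower from compound 3 to compound 4 (within the scatter), so the read-out does not separate the two groups at this position. A six-membered aromatic ring with 1 hetero atom and a five-membered one with 2 hetero atoms are thus interchangeable here, at least at this single dose. No supporting measurement is available to account for this.

As far as these compounds go, whether an amine such as morpholine or a carboxylic acid on this carbon would shift the number remains open. A single-dose read-out also says nothing about potency.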